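The source may hold more compounds than are shown below. What is called first, only, known or untested is meant among the compounds shown, and "the series" means these compounds.

Working notes on a small series read in a functional assay on the whole organism for antagonist activity, with Mus musculus as the target; on this read-out higher numbers stand for an effect only at larger amounts of compound and lower numbers for an effect already at smaller amounts. Compound 1 `CC(C#CCN(C)C)N1CCCC1=O` gives > 100 mg/kg, which is a limit of the assay and not a number. For the measured compounds named here, compound 2 `CC1CCC(=O)N1CC#CCn1ccnc1` gives a measured 0.54 mg/kg, the only true number so far. Compound 3 `CC(=O)NCC#CCn1ccnc1` gives > 100 mg/kg, again a limit. Compound 3 therefore stands with compound 1 at the limit of > 100 mg/kg in this assay, at which 2 of the 3 values shown sit. Compound 2 and compound 3 differ in more than one place, so their values show a gap but isolate no single change.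

Compound 4 `CC(=O)NCC#CCn1cncc1C` keeps compound 3 except for one change: methyl in place of hydrogen on an aromatic carbon, next to the ring nitrogen and next to the ring atom that bears a group of 8 heavy atoms. Going by the values given here, no measured pair isolates this change, so compound 3 is the only starting point for an expectation. In this assay no step beyond the scatter is expected, and another result reported only as a limit is the likelier outcome. The expected change is a number no higher from compound 3 to compound 4 (the limit leaves the size open). For compound 4 the estimate is 100 mg/kg, with an expected range from 20 mg/kg to 300 mg/kg.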

Compound 4, dose for half-maximal effect: 66 mg/kg
Compound 4: middle estimate off by 1.5-fold (0.18 log units), on the high side; the range from low to high includes it.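

In this assay, methyl in place of hydrogen on an aromatic carbon of the five-membered aromatic ring gives an at least 1.5-fold lower number from compound 3 to compound 4 (0.18 log units; that floor lies within the scatter). For the compounds shown here, this is the first change that can be read in one place, and compound 4 gives 66 mg/kg, so this position can carry a substituent and still yield a true number. The value of compound 3 remains a limit and not a number, so the step has a floor that lies within the scatter and no fixed size of its own, and it cannot show how much the methyl truly contributes: the limit of > 100 mg/kg in this assay, at which 2 of the 4 values shown sit.

The compounds shown leave open whether a longer chain such as ethyl, or a chlorine atom, on this same aromatic carbon would move the number further than methyl does, and whether methyl on one of the other ring carbons would give a similar read-out. They also leave open whether the same methyl would have any comparable effect on the ring of compound 2, whose measured value offers a firmer starting point than a limit, and they give no reason for the step.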